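Aryl replacement in a shared core, outlook for compound 3

The source may hold more compounds than are shown below. What is called first, only, known or untested is meant among the compounds shown, and "the series" means these compounds.

Compound 1 `CCCCCCC(Sc1nc(Cl)cc(Nc2nc(-c3cccc4ccccc34)cs2)n1)C(=O)O` gives 700 nM in an assay for inhibition of Polyunsaturated fatty acid 5-lipoxygenase (Homo sapiens), read by HPLC, with a stated time of 10 min; on this read-out higher numbers stand for weaker inhibition and lower numbers for stronger inhibition.
Compound 2 `CCCCCCC(Sc1nc(Cl)cc(Nc2nc(-c3ccc(Cl)cc3Cl)cs2)n1)C(=O)O` gives 1100 nM in this assay.

Within the data shown here, compound 2 carries the highest of the two numbers measured so far; its nearest neighbour is compound 1, and the two values lie within the usual scatter, so no order between them is claimed. Compound 3 `CCCCCCC(Sc1nc(Cl)cc(Nc2nc(-c3ccc(OC)cc3)cs2)n1)C(=O)O` has not yet been measured. From compound 2 it differs in one place: 4-methoxyphenyl in place of 2,4-dichlorophenyl on an aromatic carbon. Among the measured compounds shown here, the only measured step that bears on this change is a 1.6-fold higher number from compound 1 to compound 2 (0.20 log units; within the scatter), which exchanged one aromatic group for another on the same aromatic carbon and left the number within the scatter. For the measured compounds named here, no other step touches this position, and nothing measured so far involves a methoxy group. The expected size of the step in this assay is therefore none beyond the scatter, in either direction; the step that this estimate means is no change at the digits printed from compound 2 to compound 3 (within the scatter). Compound 3 is estimated at 1100 nM, with a range from 400 nM to 3500 nM.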

Compound 3, half-maximal inhibitory concentration: 1800 nM
Estimate against measurement, compound 3: 1.6-fold (0.21 log units) below, and the stated range covers the measured number.
By their numbers in this assay, from the lowest: compounds 1, 2 and 3 (each within the scatter of the next, the first and the last beyond it).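

In this assay, a 1.6-fold higher number from compound 2 to compound 3 (0.21 log units; within the scatter): with 8 heavy atoms in each group, the exchange of 2,4-dichlorophenyl for 4-methoxyphenyl, which adds one hydrogen-bond acceptor, does not separate these two compounds. The series now also holds its first step at this position beyond the scatter, a 2.6-fold higher number from compound 1 to compound 3 (0.41 log units; beyond the scatter), so the aryl group on this aromatic carbon can shift the number modestly, although compound 2 lies within the scatter of both compound 1 and compound 3. Nothing available explains either step.

The three aryl groups differ in several features at once, so the compounds shown leave open whether the modest step from naphthalen-1-yl to 4-methoxyphenyl belongs to the loss of the second ring, to the methoxy group, or to the place of substitution, and a plain phenyl group would bear directly on that question. Also open, from the compounds shown here alone, is whether an amine or a carboxylic acid in place of the methoxy group would keep the number within the scatter of compound 3 or move it beyond.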